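The compounds below may be only part of what the source reports. "The series", "measured", "known", "first", "only" and "open" are said of these compounds alone.

In an ADME assay on cells (Lymphocyte, Homo sapiens) for cytotoxicity, read by MTT assay, with a stated time of 48 h (a lower number here means a stronger inhibitor, a higher number a weaker inhibitor), the series reads:
- compound 1 `COC(=O)/C(=C\c1ccc(OC(=O)c2cc(OC)cc(OC)c2)cc1)Sc1ccnc2cc(Cl)ccc12` gives 84100 nM
- compound 2 `COC(=O)/C(=C\c1ccc(OC(=O)c2ccc(OC)c(OC)c2)cc1)Sc1ccnc2cc(Cl)ccc12` gives 51100 nM
- compound 3 `COC(=O)/C(=C\c1ccc(OC(=O)c2cc(OCc3ccccc3)c(OCc3ccccc3)c(OCc3ccccc3)c2)cc1)Sc1ccnc2cc(Cl)ccc12` gives > 100000 nM, which is a limit of the assay and not a number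

Among the compounds with values here, compound 2 stands within the scatter of compound 1, the only other compound with a number, and the step between them is a 1.6-fold lower number from compound 1 to compound 2 (0.22 log units; within the scatter).

Compound 4 `COC(=O)/C(=C\c1ccc(OC(=O)c2cc(OC)c(OC)c(OC)c2)cc1)Sc1ccnc2cc(Cl)ccc12` is reached from compound 2 by this change: methoxy in place of hydrogen on an aromatic carbon. In words, methoxy replaces hydrogen on an aromatic carbon, turning 3,4-dimethoxyphenyl into 3,4,5-trimethoxyphenyl.

Within the data shown here, no measured step adds a methoxy group to this ring. The nearest evidence is the exchange of 3,5-dimethoxyphenyl for 3,4-dimethoxyphenyl, measured as a 1.6-fold lower number from compound 1 to compound 2 (0.22 log units; within the scatter). Compound 3 has only a limit, so it sets no step size.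

On that basis, no step beyond the scatter is expected in this assay. The expected step is a 1.2-fold higher number from compound 2 to compound 4 (0.07 log units; within the scatter). For compound 4 the estimated value is 60000 nM, with an expected range from 28000 nM to 100000 nM.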

Compound 4, half-maximal inhibitory concentration: 35200 nM
For compound 4 the middle estimate is 1.7-fold (0.23 log units) above the measured one; measured number inside the range.
By their numbers in this assay, from the lowest: compounds 4, 2 and 1 (each within the scatter of the next, the first and the last beyond it). At a limit, above all of these: compound 3.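

In this assay, putting methoxy on the aromatic carbon ortho to a methoxy group and meta to a large group gives a 1.5-fold lower number from compound 2 to compound 4 (0.16 log units; within the scatter), so this change on the 3,4-dimethoxyphenyl ring cannot be told from repeat scatter. Set against the 3,5-dimethoxyphenyl ester, however, the 3,4,5-trimethoxyphenyl ester gives a 2.4-fold lower number from compound 1 to compound 4 (0.38 log units; beyond the scatter), the only step among the numbered compounds that passes the scatter, and it is modest. Nothing shown gives a reason for either step.

Compound 3 gives > 100000 nM, which is a limit and not a number, so steps to it cannot be read: the limit of > 100000 nM in this assay, at which 1 of the 4 values shown sits. On these data alone, whether an amine, a hydroxyl or a fluorine at this ring position would give a step beyond the scatter stays open.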